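The compounds below may be only part of what the source reports. "The series", "measured", "known", "first", "only" and "open" are said of these compounds alone.

Measured compounds and values:
compound 1, `[O-][S+](CCC(F)(Cl)C(F)(F)Cl)c1nc2ccccc2s1` — 13500 nM
compound 2, `FC(F)(Cl)C(F)(Cl)CCSc1nc2ccc(Cl)cc2s1` — > 120000 nM, a limit of the assay
compound 3, `FC(F)(Cl)C(F)(Cl)CCSc1nc2ccccc2s1` — > 120000 nM, a limit of the assay

Within the data shown here, in a functional assay on HepG2 cells (Homo sapiens) for cytotoxicity, read by MTT assay, with a stated time of 48 h (on this read-out lower numbers stand for stronger inhibition and higher numbers for weaker inhibition), compound 1 gives 13500 nM, the only number in the set. For compound 2 the read-out in this assay is a limit, > 120000 nM. For compound 3 the read-out in this assay is likewise a limit, > 120000 nM. The change chloro in place of hydrogen on an aromatic carbon gives a step that the two limits leave unreadable from compound 3 to compound 2, and its size cannot be read because both values sit at the limit of > 120000 nM in this assay, at which 2 of the 3 values shown sit. How the core of compound 1 differs from the core of compound 3 is not broken down here; what the two values show is that compound 1 has a number where compound 3 has only a limit.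

Compound 4, `[O-][S+](CCC(F)(Cl)C(F)(F)Cl)c1nc2ccc(Cl)cc2s1`, is not yet measured in this assay. It differs from compound 1 by chloro in place of hydrogen on an aromatic carbon, which is the same change as that made from compound 3 to compound 2, at a place described in identical words. Among the measured compounds shown here, the one measured instance of this change leaves its size unreadable, so no precedent sets the expected size of the step from compound 1 to compound 4. The step of a 1.2-fold lower number from compound 1 to compound 4 (0.09 log units; within the scatter) is expected to stay within the usual scatter, resting on the value of compound 1, 13500 nM, as the only anchor. For compound 4 the expected value in this assay is 11000 nM, with a range from 4000 nM to 35000 nM.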

Compound 4, half-maximal inhibitory concentration: 6900 nM
For compound 4 the middle estimate is 1.6-fold (0.20 log units) above the measured one, within the range that was stated.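

In this assay, chloro in place of hydrogen on an aromatic carbon of the core of compound 1 gives a 2.0-fold lower number from compound 1 to compound 4 (0.29 log units; within the scatter), so on this core the change produces no step beyond the usual scatter. Among these compounds, this rests on a single pair, and it shows only that compound 4, like compound 1, gives a number rather than a limit. It does not show whether the change behaves alike on the two cores, because the matching step from compound 3 to compound 2 cannot be read, both of its ends being limits: the limit of > 120000 nM in this assay, at which 2 of the 4 values shown sit.

The compounds shown cover only hydrogen and chloro at this one aromatic carbon, so how an amine or a carboxylic acid would read there in either core remains open. Also open, on these data alone, is what a longer chain in place of the chain carrying fluorine and chlorine would do to the read-out on the core of compound 1, where a number can be read.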